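The source may hold more compounds than are shown below. What is called first, only, known or untested is meant among the compounds shown, and "the series" means these compounds.

Compound 1 `CCC1(Cc2ccccc2)OS(=O)(=O)C=C1OCc1ccc(Cl)cc1`: > 200000 nM
Compound 2 `CCC1(Cc2ccccc2)OS(=O)(=O)C=C1OCC=C(C)C`: 112000 nM
Compound 3 `CCC1(Cc2ccccc2)OS(=O)(=O)C=C1OCCc1ccccc1`: 48000 nM

Three compounds share one core and differ only in the group on a saturated chain carbon bound to an oxygen on an unsaturated carbon. In an ADME assay on HEL cells (Homo sapiens) for cytotoxicity, with a stated time of 3 days (on this read-out lower numbers stand for higher toxicity in this test and higher numbers for lower toxicity in this test), compound 1 gives > 200000 nM, which is a limit of the assay and not a number. In this assay compound 2 gives 112000 nM, and compound 3 gives 48000 nM, the lowest of the two numbers shown. The step of a 2.3-fold lower number from compound 2 to compound 3 (0.37 log units; beyond the scatter) lies beyond the scatter, as does an at least 4.1-fold lower number from compound 1 to compound 3 (0.61 log units; beyond the scatter), so compound 3 stands as the most toxic of the measured set.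

Compound 4 `CCC1(Cc2ccccc2)OS(=O)(=O)C=C1OCc1ccc(C)cc1` differs from compound 3 by 4-methylphenyl in place of benzyl on a saturated chain carbon bound to an oxygen on an unsaturated carbon. The step of an at least 4.1-fold lower number from compound 1 to compound 3 (0.61 log units; beyond the scatter) is the one that bears on this change, since it runs in the opposite direction, from a substituted benzyl-type ether toward a phenethyl ether, and it moved the number at least modestly downward. Reversing that direction, the step from compound 3 to compound 4 is expected to raise the number, a 2.5-fold higher number from compound 3 to compound 4 (0.40 log units; beyond the scatter). Compound 4 is therefore estimated to give 120000 nM, with a range from 50000 nM to 200000 nM.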

Compound 4, half-maximal cytotoxic concentration: 41500 nM
Compound 4: the middle estimate sits 2.9-fold (0.46 log units) above what was measured, outside the stated range (below it).
By their numbers in this assay, from the lowest: compounds 4 and 3 (each within the scatter of the next); then compound 2. At a limit, above all of these: compound 1.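

In this assay, moving from phenethyl to 4-methylbenzyl rearranges the same atoms, yet the two compounds cannot be told apart (a 1.2-fold lower number from compound 3 to compound 4 (0.06 log units; within the scatter)). Compound 4 also sits clearly under the compound with the non-aromatic group (a 2.7-fold lower number from compound 2 to compound 4 (0.43 log units; beyond the scatter)), so among these compounds, the 2-methylprop-1-en-1-yl and 4-methylphenyl groups give numbers that differ beyond the scatter. Methyl in place of chloro on an aromatic carbon is the first change shown on the ring itself, and it gives an at least 4.8-fold lower number from compound 1 to compound 4 (0.68 log units; beyond the scatter), a floor only because compound 1 stands at a limit and not a number: the limit of > 200000 nM in this assay, at which 1 of the 4 values shown sits.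

On these data alone, it remains open where a bromo or methoxy on that aromatic ring would fall relative to the methyl and chloro. As far as these compounds go, how an amine, a carboxylic acid or a longer chain at this position would read in this assay also remains open.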